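Notes on the benzimidazole nitrogen in this series

The source may report more compounds than this note shows. Statements on the series, on what has been measured and on what is new or still open speak of the compounds shown alone.

Compound 1 `CCN(CC)CCCn1c(N)c(-c2nc3ccccc3[nH]2)c2nc(C#N)c(C#N)nc21`: 1800 nM
Compound 2 `N#Cc1nc2c(-c3nc4ccccc4[nH]3)c(N)n(CCCN3CCCCC3)c2nc1C#N`: 3460 nM
Compound 3 `CCN(CC)CCCn1c(N)c(-c2nc3ccccc3n2C)c2nc(C#N)c(C#N)nc21`: not yet measured

In a functional assay on K562 cells (Homo sapiens) for antiproliferative activity, read by MTT assay, with a stated time of 48 h (on this read-out lower numbers stand for stronger inhibition and higher numbers for weaker inhibition), compound 1 gives 1800 nM and compound 2 gives 3460 nM. These two values lie within the scatter of each other, so compound 1 has no clear rank.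

Compound 3 differs from compound 1 by methyl in place of hydrogen on an aromatic nitrogen. Among the compounds with values here, the only measured step, a 1.9-fold higher number from compound 1 to compound 2 (0.28 log units; within the scatter), replaces diethylamino with piperidin-1-yl on the chain and leaves this nitrogen untouched. It therefore gives a rough sense of scale but no direction. Within the data shown here, with no direct precedent, a modest move towards a higher number is tentatively expected, with a wide range that also covers no change. The expected change is a 1.7-fold higher number from compound 1 to compound 3 (0.22 log units; within the scatter). For compound 3 the estimated value is 3000 nM, with an expected range of 900 nM to 10000 nM.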

Compound 3, half-maximal inhibitory concentration: 3270 nM
Compound 3: the middle estimate sits 1.1-fold (0.04 log units) below what was measured; measured number inside the range.
By their numbers in this assay, from the lowest: compounds 1, 3 and 2 (each within the scatter of the next).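

In this assay, within the data shown here, the step of methyl in place of hydrogen on an aromatic nitrogen gives a 1.8-fold higher number from compound 1 to compound 3 (0.26 log units; within the scatter) and is the first reading at this position, which the chain change between the earlier compounds left untouched. With diethylamino on the chain, the hydrogen on this nitrogen is therefore not needed for a value in this range, as replacing it leaves compound 3 within the scatter of compound 1. Nothing measured here bears on what lies behind this result.

Open, from the compounds shown here alone, is whether a larger group on this nitrogen, such as ethyl, benzyl or a longer chain ending in an amine, would also stay within the scatter of compound 1. Also open, going by these compounds, is whether methyl at this nitrogen reads the same with piperidin-1-yl on the chain, as in compound 2.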